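Trifluoromethyl to trifluoromethoxy on a benzyl-substituted nucleoside core

The compounds below may be only part of what the source reports. "The series", "measured", "known", "first", "only" and "open" are said of these compounds alone.

Compound 1 `OC[C@H]1O[C@@H](n2cnc3c(NCc4cccc(C(F)(F)F)c4)ncnc32)[C@H](O)[C@@H]1O` is the reference. In a functional assay on HOS cells (Homo sapiens) for antiproliferative activity, with a stated time of 72 h (a lower number here means a stronger inhibitor, a higher number a weaker inhibitor), compound 1 gives only a limit of > 166000 nM. Compound 2 `OC[C@H]1O[C@@H](n2cnc3c(NCc4ccc(C(F)(F)F)cc4)ncnc32)[C@H](O)[C@@H]1O` has the same atoms joined differently; how the two cores differ is counted in 4-(trifluoromethyl)phenyl in place of 3-(trifluoromethyl)phenyl on a saturated chain carbon bound to a nitrogen on an aromatic ring. In this assay compound 2 likewise gives only a limit of > 166000 nM. The step from compound 1 to compound 2 is a step that the two limits leave unreadable from compound 1 to compound 2. Compound 3 `OC[C@H]1O[C@@H](n2cnc3c(NCc4cccc(OC(F)(F)F)c4)ncnc32)[C@H](O)[C@@H]1O` differs from compound 1 by trifluoromethoxy in place of trifluoromethyl on an aromatic carbon. In this assay compound 3 again gives only a limit of > 166000 nM. The step from compound 1 to compound 3 is a step that the two limits leave unreadable from compound 1 to compound 3; all three values sit at the limit of > 166000 nM in this assay, at which 3 of the 3 values shown sit.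

Compound 4 `OC[C@H]1O[C@@H](n2cnc3c(NCc4ccc(OC(F)(F)F)cc4)ncnc32)[C@H](O)[C@@H]1O` is not yet measured; it differs from compound 2 by trifluoromethoxy in place of trifluoromethyl on an aromatic carbon, the same kind of change as from compound 1 to compound 3, but here para to a large group rather than meta to a large group. In this assay the step from compound 2 to compound 4 is expected to be a number no higher from compound 2 to compound 4 (the limit leaves the size open), resting on the unreadable step from compound 1 to compound 3 with both at the limit. Compound 4 is therefore estimated at 166000 nM, most likely reported again only as a limit.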

Compound 4, half-maximal inhibitory concentration: > 166000 nM
Compound 4: no number, only a limit (the forecaster's own chance of this, stated with the estimate: 85%); the middle value lies on the limit itself.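

In this assay compound 4 gives > 166000 nM, a limit and not a number. Compound 2 also gives only a limit, so no step can be read from compound 2 to compound 4. All four compounds sit at the same limit: the limit of > 166000 nM in this assay, at which 4 of the 4 values shown sit.

Still open is whether trifluoromethoxy in place of trifluoromethyl, or the other differences among these compounds, changes antiproliferative activity at all.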